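Spirooxindole-quinoxaline triazoles: antiproliferative read-out at the assay limit

This account rests on a few compounds, and the source may have more. Where it says the series, first, only, none or still open, it means among the compounds named here.

Measured so far:
- compound 1 `Cc1cccc(-n2nncc2CN2C(=O)C3(C(C#N)=C(N)Oc4c3c3nc5ccccc5nc3c3ccccc43)c3ccccc32)c1` — > 50000 nM
- compound 2 `N#CC1=C(N)Oc2c(c3nc4ccccc4nc3c3ccccc23)C12C(=O)N(Cc1cnnn1-c1ccc([N+](=O)[O-])cc1)c1ccccc12` — > 50000 nM
- compound 3 `N#CC1=C(N)Oc2c(N)cc3nc4ccccc4nc3c2C12C(=O)N(Cc1cnnn1-c1ccccc1Cl)c1ccccc12` — > 50000 nM

All three values come from a functional assay on HCT-116 cells (Homo sapiens) for antiproliferative activity, read by MTT assay, with a stated time of 48 h; on this read-out lower numbers stand for stronger inhibition and higher numbers for weaker inhibition. For compound 1 the value > 50000 nM is a limit of the assay, not a number. For compound 2 the value > 50000 nM is likewise a limit. For compound 3 the value > 50000 nM is again a limit. Among the measured compounds shown here, the one single-point step among the measured compounds, a step that the two limits leave unreadable from compound 1 to compound 2, cannot be read, since both ends sit at the limit; this is summarised by the limit of > 50000 nM in this assay, at which 3 of the 3 values shown sit.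

Compound 3 therefore stands where every other measured compound stands: at the limit, with no resolved number. Compound 4 `N#CC1=C(N)Oc2c(N)cc3nc4ccccc4nc3c2C12C(=O)N(Cc1cnnn1-c1ccc(F)c(Cl)c1)c1ccccc12` differs from it by 3-chloro-4-fluorophenyl in place of 2-chlorophenyl on an aromatic nitrogen. For the measured compounds named here, no measured step bears on an exchange of this kind, and the only step that exists in the set is unreadable. Nothing in the series points to a change beyond the scatter in this assay, and the shared core and the triazole-linked aryl pattern are retained.

Compound 4 is expected to remain at the limit, with an estimated step that the limit leaves unreadable from compound 3 to compound 4. The estimate for compound 4 is 80000 nM, in the range 30000 nM to 300000 nM.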

Compound 4, half-maximal inhibitory concentration: > 50000 nM
Compound 4: no number, only a limit (the forecaster's own chance of this, stated with the estimate: 85%); the middle value does not contradict the limit.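

Compound 3 and compound 4 both sit at a limit in this assay, so the exchange between them gives no readable step, and the series offers no resolved number: the limit of > 50000 nM in this assay, at which 4 of the 4 values shown sit.

The compounds shown leave open whether any aryl group or other change on the shared core would bring a resolved number in this assay.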